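Carboxy to aminomethyl on the shared core

The source may report more compounds than this note shows. Statements on the series, on what has been measured and on what is new or still open speak of the compounds shown alone.

In an ADME assay on cells (spleen, Mus musculus, strain C57BL/6) for inhibition, read by flow cytometry and propidium iodide staining, with a stated time of 24 h, at 37 degrees C (on this read-out lower numbers stand for an effect already at smaller amounts and higher numbers for an effect only at larger amounts of compound), compound 1 (`CC(C)(O)c1cn(CC(=O)NCc2ccccc2)nn1`) gives 1600 uM. Compound 2 (`O=C(Cn1cc(C(=O)O)nn1)NCc1ccccc1`) has no single number and stands only as "non-toxic" (no number reported). The structure under test is compound 3 (`NCc1cn(CC(=O)NCc2ccccc2)nn1`). The change aminomethyl in place of carboxy on an aromatic carbon puts aminomethyl in place of carboxy on an aromatic carbon. Without a number for compound 2, no step size can be stated. Among the measured compounds shown here, the direction expected in this assay is toward a measurable effect, with compound 1 at 1600 uM as the only numerical guide. The expected value for compound 3 is 1000 uM, with an estimated range of 250 uM to 4000 uM.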

Compound 3, concentration for half-maximal effect: > 2000 uM
Compound 3 ended at the assay's limit; the forecaster's own chance of this, stated with the estimate: 30%; middle value at least 2.0-fold (0.30 log units) away from the limit.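

In this assay compound 3 stands at a limit and not at a number: the limit of > 2000 uM in this assay, at which 1 of the 3 values shown sits. Aminomethyl in place of 1-hydroxy-1-methylethyl on this aromatic carbon gives an at least 1.2-fold higher number from compound 1 to compound 3 (0.09 log units; that floor lies within the scatter) and brings no measurable effect into view at this position. The step between carboxy and aminomethyl cannot be read, as neither compound 2 nor compound 3 has a number.

Open: whether a methyl ester or a longer chain ending in an amine on this aromatic carbon would give a value short of the limit.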